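An Aromatic Ring Gives Way to a Non-Aromatic One

The compounds below may be only part of what the source reports. "The series", "measured", "known", "first", "only" and "open" are said of these compounds alone.

In a functional assay on NCI-H1993 cells (Homo sapiens) for inhibition, read by CCK-8 assay, with a stated time of 72 h (on this read-out higher numbers stand for weaker inhibition and lower numbers for stronger inhibition), compound 1 `CC(c1c(F)cc2ncccc2c1F)n1cnc2ncc(-c3ccccc3)nc21` gives 514 nM, compound 2 `CC(c1c(F)cc2ncccc2c1F)n1cnc2ncc(-c3cnc4ccccc4c3)nc21` gives 46.1 nM, and compound 3 `CC(NC/N=C/c1cnn(C)c1)c1ccc2ncccc2c1` gives 197 nM. Compound 3 therefore holds the second highest of the three numbers, with a weaker result than compound 2 and a stronger one than compound 1.

Compound 4 `CC(NC/N=C/C1=CCNCC1)c1ccc2ncccc2c1` differs from compound 3 in one place, on a carbon with a double bond to nitrogen: a group of 6 heavy atoms (5 carbon, 1 nitrogen; one six-membered non-aromatic ring with 1 hetero atom) in place of a group of 6 heavy atoms (4 carbon, 2 nitrogen; one five-membered aromatic ring with 2 hetero atoms), on a carbon with a double bond to nitrogen.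

Within the data shown here, only one measured step bears on this change, and only loosely: an 11-fold lower number from compound 1 to compound 2 (1.05 log units; beyond the scatter), with quinolin-3-yl in place of phenyl on an aromatic carbon. That large step shows that exchanging a ring group can matter, but it joins two aromatic groups on a core other than that of compound 3. Among the measured compounds shown here, no measured step replaces an aromatic ring with a non-aromatic one, so the direction remains uncertain.

A modest rise is tentatively expected, namely a 2.3-fold higher number from compound 3 to compound 4 (0.36 log units; beyond the scatter) in this assay. For compound 4 the estimated value is 450 nM, with an expected range from 110 nM to 1800 nM.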

Compound 4, half-maximal inhibitory concentration: 2660 nM
Beside the measured number, compound 4's estimate is 5.9-fold (0.77 log units) below it; measured number above the stated range.
By their numbers in this assay, from the lowest: compound 2; then compound 3; then compound 1; then compound 4.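

In this assay the exchange on this carbon with a double bond to nitrogen gives a 14-fold higher number from compound 3 to compound 4 (1.13 log units; beyond the scatter) and so shows that this position responds strongly to the group it carries. Among these compounds, the only earlier step swapped one aromatic group for another on a different core, whereas this one shows that, on the core of compound 3, replacing 1-methyl-1H-pyrazol-4-yl with a six-membered non-aromatic ring costs much of the inhibition. No supporting measurement explains why the inhibition falls.

The two groups differ at once in ring size, in aromatic character and in hydrogen-bond donors and acceptors, and the compounds shown do not tell these features apart. Also open, as far as these compounds go, is how this position would respond to a simple amine, a carboxylic acid or a longer chain in place of either ring.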